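This account rests on a few compounds, and the source may have more. Where it says the series, first, only, none or still open, it means among the compounds named here.

In a physicochemical assay for metabolic stability, read by LC-MS, in phosphate buffer, with a stated time of 3 h, at pH 7.4, tested at 50 uM (a higher number here means that more of the compound is left, a lower number that less of the compound is left), the question is simply how much of a compound survives in buffer. Compound 3 `CCOC(=O)c1cccc(NC(=O)[C@@H]2C[C@H](SC3=C(C(=O)O)N4C(=O)[C@H]([C@@H](C)O)[C@H]4[C@H]3C)CN2)c1` returns only a limit there, > 95%. Compound 1 `CCOC(=O)C1=C(S[C@@H]2CN[C@H](C(=O)Nc3cccc(C(=O)OCC)c3)C2)[C@H](C)[C@@H]2[C@@H]([C@@H](C)O)C(=O)N12` likewise returns only a limit, > 95%. Compound 2 `COC(=O)OCOC(=O)C1=C(S[C@@H]2CN[C@H](C(=O)Nc3cccc(C(=O)O)c3)C2)[C@H](C)[C@@H]2[C@@H]([C@@H](C)O)C(=O)N12` also returns only a limit, > 95%. Put together, (the limit of > 95% in this assay, at which 3 of the 3 values shown sit), so none of the three gives a number that can be set against another.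

Compound 4 `CC(C)C(=O)OCOC(=O)c1cccc(NC(=O)[C@@H]2C[C@H](SC3=C(C(=O)O)N4C(=O)[C@H]([C@@H](C)O)[C@H]4[C@H]3C)CN2)c1` has not yet been measured. It differs from compound 3 by (isopropylcarbonyl)oxy in place of methyl on a saturated chain carbon bound to an oxygen next to a carbonyl group. For the measured compounds named here, the only measured step that touches the same ester, a step that the two limits leave unreadable from compound 1 to compound 3, is left unreadable by the two limits at its ends, so it tells nothing about size or direction, and no other measured step bears on the change from compound 3 to compound 4. What the data do show is that all three measured compounds, with three different groups on that ester oxygen, have stayed at the limit. On that basis compound 4 is expected to remain near the limit as well, with a step of a number at least 3 percentage points lower from compound 3 to compound 4 (that floor lies within the scatter) that is not expected to go beyond the scatter. The estimate for compound 4 in this assay is 92%, within a range from 75% to 99%.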

Compound 4, percent of the compound remaining: > 95%
Compound 4: no number, only a limit; the forecaster's own chance of this, stated with the estimate: 60%; middle value at least 3 percentage points away from the limit.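

Compound 4 gives only a limit in this assay, > 95%, so the step to it from compound 3 cannot be read, and all four compounds stand at the same limit: the limit of > 95% in this assay, at which 4 of the 4 values shown sit.

As far as these compounds go, how much the four compounds differ in what remains in buffer, and whether any group on that ester oxygen would lower it, stays open.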